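The compounds below may be only part of what the source reports. "The series", "measured", "known", "first", "only" and "open" are said of these compounds alone.

Compounds measured so far:
compound 1, `COc1cc(-c2ccnc3cc(-c4ccc(Cl)cc4)nn23)cc(OC)c1OC`, 2320 nM;
compound 2, `COc1cc(-c2ccnc3cc(-c4ccc5cc[nH]c5c4)nn23)cc(OC)c1OC`, 23 nM;
compound 3, `COc1cc(-c2cc3nccc(-c4c[nH]c5ccccc45)n3n2)cc(OC)c1OC`, > 10000 nM.

In a functional assay on MCF7 cells (Homo sapiens) for inhibition, read by CCK-8 assay, with a stated time of 48 h (on this read-out lower numbers stand for stronger inhibition and higher numbers for weaker inhibition), compound 2 gives the lowest of the two numbers; its nearest neighbour is compound 1, and the step of a 100-fold lower number from compound 1 to compound 2 (2.00 log units; beyond the scatter), 1H-indol-6-yl in place of 4-chlorophenyl on an aromatic carbon, separates them. For compound 3 the value is a limit of this assay, not a number (the limit of > 10000 nM in this assay, at which 1 of the 3 values shown sits).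

Compound 4, `COc1ccc(-c2cc3nccc(-c4cc(OC)c(OC)c(OC)c4)n3n2)cc1F`, has not yet been measured. It differs from compound 2 by 3-fluoro-4-methoxyphenyl in place of 1H-indol-6-yl on an aromatic carbon. For the measured compounds named here, the only measured step that bears on this change is a 100-fold lower number from compound 1 to compound 2 (2.00 log units; beyond the scatter), which went in the opposite direction: a single six-membered aromatic ring of carbon only was replaced by the indole, and the number fell far beyond the scatter. Compound 4 restores a group of that simpler kind, so a large step upward is expected, estimated as a 65-fold higher number from compound 2 to compound 4 (1.81 log units; beyond the scatter). Compound 4 is therefore expected to give about 1500 nM in this assay, within 300 nM to 8000 nM.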

Compound 4, half-maximal inhibitory concentration: 183 nM
Compound 4: middle estimate off by 8.2-fold (0.91 log units), on the high side, and the stated range ends above it.
By their numbers in this assay, from the lowest: compound 2; then compound 4; then compound 1. At a limit, above all of these: compound 3.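

Among the groups on this aromatic carbon, the indole is no longer the only one that gives a low number in this assay: the exchange of 4-chlorophenyl for 3-fluoro-4-methoxyphenyl gives a 13-fold lower number from compound 1 to compound 4 (1.10 log units; beyond the scatter). 1H-indol-6-yl still holds the lowest number, with an 8.0-fold higher number from compound 2 to compound 4 (0.90 log units; beyond the scatter), but this gap is smaller than the one that separated the indole from 4-chlorophenyl. A six-membered aromatic ring of carbon only at this place therefore does not by itself account for the whole of the earlier loss, since the substituents on that ring also change the number.

Nothing measured here gives a cause for either step. As far as these compounds go, it also stays open whether the fluorine or the methoxy group carries the difference, and how a pyridine ring or a morpholine would fare at this carbon.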